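The source may hold more compounds than are shown below. What is called first, only, known or untested is meant among the compounds shown, and "the series" means these compounds.

Measured so far in a functional assay on HL-60 cells (Homo sapiens) for inhibition, read by CCK-8 assay, with a stated time of 48 h, tested at 20 uM; a higher number here means more inhibition of growth at the concentration tested, a lower number less inhibition of growth:
- compound 1 `Cc1ccc(S(=O)(=O)Oc2ccccc2/C=C(\C#N)C(=O)Nc2nnc(C)s2)cc1`: 78%
- compound 2 `COc1ccc(S(=O)(=O)Oc2ccccc2/C=C(\C#N)C(=O)Nc2nnc(-c3cccs3)s2)cc1`: 67%

Compound 2, at 67%, is the lower of the two numbers, and compound 1, at 78%, lies above it by more than the scatter. The two differ in more than one place, so their gap cannot be assigned to any single change.

Next is compound 3 `N#C/C(=C\c1ccccc1OS(=O)(=O)c1ccc([N+](=O)[O-])cc1)C(=O)Nc1nnc(-c2cccs2)s1`, which turns 4-methoxyphenyl into 4-nitrophenyl: nitro in place of methoxy on an aromatic carbon. The exchanged group sits para to a large group. Going by the values given here, no measured pair isolates this change in this assay, so no direction is favoured and no step beyond the scatter is expected. The expectation rests on compound 2 at 67%, the closest measured structure.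

The estimated step of a number 1 percentage points lower from compound 2 to compound 3 (within the scatter) is expected to remain small.

For compound 3 the estimated value is 66%, with an expected range of 47% to 84%.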

Compound 3, percent growth inhibition at one concentration: 23%
Beside the measured number, compound 3's estimate is 43 percentage points above it, and the stated range ends above it.
By their numbers in this assay, from the lowest: compound 3; then compound 2; then compound 1.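

Nitro in place of methoxy on 4-methoxyphenyl gives a number 44 percentage points lower from compound 2 to compound 3 (beyond the scatter) in this assay, the first comparison in this series that differs in one place. The position para to a large group is therefore not indifferent to its substituent, at least with the rest of compound 2 held fixed. Nothing measured here accounts for the size or direction of this step.

Only methoxy and nitro have been compared at this position on an otherwise identical structure, so one step cannot show whether the drop is specific to nitro or would follow other replacements of methoxy. As far as these compounds go, what an amine, a carboxylic acid or a chlorine at this position would give remains open, as does the effect of the same exchange with the rest of compound 1 in place.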